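Swapping Nitro for Chloro on a Sulfur Ring

This account rests on a few compounds, and the source may have more. Where it says the series, first, only, none or still open, it means among the compounds named here.

Compound 1 `O=C(/C=C/c1ccc([N+](=O)[O-])o1)c1ccc(C2CCCCC2)cc1`: 4400 nM
Compound 2 `O=C(/C=C/c1ccc([N+](=O)[O-])s1)c1ccc(-n2ccnc2)cc1`: 9400 nM

In a functional assay on U-251 cells (Homo sapiens) for inhibition, read by sulforhodamine B assay, with a stated time of 72 h (a lower number here means that less compound is needed, a higher number that more compound is needed for the effect), compound 2 gives 9400 nM, the higher of the two numbers, and its gap to compound 1 lies beyond the usual scatter. More of compound 2 is therefore needed for the same effect.

Compound 3 `O=C(/C=C/c1ccc(Cl)s1)c1ccc(-n2ccnc2)cc1` keeps the rest of compound 2 and changes one group: chloro in place of nitro on an aromatic carbon. Among the measured compounds shown here, both measured compounds carry nitro, so no measured pair shows what this exchange does, and any forecast is uncertain. A moderate rise in the number seems more likely than a fall or no change. The estimated change is a 1.6-fold higher number from compound 2 to compound 3 (0.20 log units; within the scatter) in this assay. Compound 3 is expected to give about 15000 nM, with an estimated range of 5000 nM to 50000 nM.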

Compound 3, half-maximal effective concentration: 35100 nM
Estimate against measurement, compound 3: 2.3-fold (0.37 log units) below; measured number inside the range.
By their numbers in this assay, from the lowest: compound 1; then compound 2; then compound 3.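

At the ring position next to the ring sulfur, the group clearly matters: in this assay, chloro in place of nitro brings a 3.7-fold higher number from compound 2 to compound 3 (0.57 log units; beyond the scatter) and this modest step lies beyond the usual scatter. Nitro and chloro are therefore not interchangeable here, as the compound keeping nitro needs less material for the same effect. The data show the size and direction of this change, but no measurement available here accounts for it.

The compounds shown leave open what an amine, a methoxy group or a carboxylic acid would do at this position. They also leave open whether the same exchange would give a similar step on the core of compound 1, which differs from compound 2 in more than one place.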